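The source may report more compounds than this note shows. Statements on the series, on what has been measured and on what is new or still open speak of the compounds shown alone.

Measured in a functional assay on KB cells (Homo sapiens) for inhibition, read by sulforhodamine B assay; a higher number here means a weaker inhibitor of growth, a lower number a stronger inhibitor of growth:
- compound 1 `Cc1ccc2[nH]c(-c3ccc(-c4ccc(-c5cccc(Cl)c5)cc4)cc3)nc2c1`: 2260 nM
- compound 2 `Clc1cccc(-c2ccc(-c3ccc(-c4nc5ccccc5[nH]4)cc3)cc2)c1`: 32300 nM
- compound 3 `Oc1cccc2[nH]c(-c3ccc(-c4ccc(-c5ccc(OC(F)(F)F)cc5)cc4)cc3)nc12`: 3310 nM

Compound 1 and compound 3 lie within the scatter of each other, while compound 2 stands well apart. Compound 4 `Cc1ccc2[nH]c(-c3ccc(-c4ccc(-c5ccc(C(F)(F)F)cc5)cc4)cc3)nc2c1` keeps the core of compound 1, methyl included, and changes only the far end: 4-(trifluoromethyl)phenyl in place of 3-chlorophenyl on an aromatic carbon. Among the measured compounds shown here, the one measured step, a 14-fold higher number from compound 1 to compound 2 (1.16 log units; beyond the scatter), is large but removes that methyl, so it says little about this change. Compound 3, at 3310 nM, also ends in a fluorinated ring, but its core differs, so it offers only loose support. No large shift is therefore expected. The estimated step is a 1.1-fold higher number from compound 1 to compound 4 (0.04 log units; within the scatter). For compound 4 the expected value is 2500 nM, with an estimated range of 900 nM to 7000 nM.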

Compound 4, concentration for 50% growth inhibition: 41200 nM
Compound 4: middle estimate off by 16-fold (1.22 log units), on the low side; measured number outside the range, above it.
By their numbers in this assay, from the lowest: compounds 1 and 3 (each within the scatter of the next); then compounds 2 and 4 (each within the scatter of the next).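

In this assay, the far ring is shown to matter in its own right: with the methyl kept, 4-(trifluoromethyl)phenyl in place of 3-chlorophenyl gives an 18-fold higher number from compound 1 to compound 4 (1.26 log units; beyond the scatter) and so the methyl is not the only place where a large step can arise. Nothing measured here explains this step.

This one swap changes both the group and its place on the ring, and the compounds shown do not separate the two. As far as these compounds go, a 4-chlorophenyl or 3-(trifluoromethyl)phenyl end could do so, while an amine or a carboxylic acid on that ring remains unexplored.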